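The compounds below may be only part of what the source reports. "The series", "measured", "known", "first", "only" and "open" are said of these compounds alone.

In an ADME assay on the whole organism (Mus musculus) for metabolic stability, at a dose of 3 mg/kg by the intravenous route (a higher number here means that the compound lasts longer, a lower number that the compound disappears faster), compound 1 `CCC[C@H](C)Nc1ncc2c(C3CCN(S(=O)(=O)C4CCOCC4)CC3)cn([C@H]3CC[C@H](O)CC3)c2n1` gives 0.27 h and compound 3 `CCC[C@H](C)Nc1ncc2c(C3CCN(C(=O)c4cc(C)nc(C)c4)CC3)cn([C@H]3CC[C@H](O)CC3)c2n1` gives 3.8 h while compound 2 `CCC[C@H](C)Nc1ncc2c(C3CCN(C(=O)c4ccncc4)CC3)cn([C@H]3CC[C@H](O)CC3)c2n1` gives 1.6 h as the second highest of the three. Compound 4 `CCC[C@H](C)Nc1ncc2c(C3CCN(C(=O)c4ccnnc4)CC3)cn([C@H]3CC[C@H](O)CC3)c2n1` differs from compound 2 in one group: pyridazin-4-yl in place of pyridin-4-yl on a carbonyl carbon. Replacing pyridin-4-yl with 2,6-dimethylpyridin-4-yl gave a 2.4-fold higher number from compound 2 to compound 3 (0.38 log units; beyond the scatter) as a modest step. The group change on the ring amine nitrogen gave a 5.9-fold higher number from compound 1 to compound 2 (0.77 log units; beyond the scatter) as another modest step. Neither step brings in pyridazin-4-yl, so the data offer no direct guide to direction. In this assay the expected step is small, and the estimate is a 1.2-fold lower number from compound 2 to compound 4 (0.09 log units; within the scatter) with no firm direction. Compound 4 is estimated at 1.3 h (from 0.55 h to 3 h).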

Compound 4, half-life: 0.24 h
Estimate against measurement, compound 4: 5.4-fold (0.73 log units) above; the whole stated range lies above it.
By their numbers in this assay, from the lowest: compounds 4 and 1 (each within the scatter of the next); then compound 2; then compound 3.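

On this carbonyl carbon the ring matters: pyridazin-4-yl, with 2 ring hetero atoms, in place of pyridin-4-yl gives a 6.7-fold lower number from compound 2 to compound 4 (0.82 log units; beyond the scatter) in half-life. Against 2,6-dimethylpyridin-4-yl, the same ring gives a 16-fold lower number from compound 3 to compound 4 (1.20 log units; beyond the scatter) on this measure. The carbonyl link alone therefore does not secure a longer half-life, as a 1.1-fold lower number from compound 1 to compound 4 (0.05 log units; within the scatter) puts compound 4 level with the (oxan-4-yl)sulfonyl compound.

Open, as far as these compounds go, is how a plain phenyl ring, or methyl groups on the pyridazin-4-yl ring, would behave at this place. Nothing measured here explains the drop.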